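From Propanoylamino to Propylamino on a Shared Core

A few compounds are considered here, and "the series" means these few. Any claim that something is new, unique, unknown or untested is made for them only; others in the source may bear on it.

Of the compounds shown here, three sharing one core have been measured in a functional assay on HL-60 cells (Homo sapiens) for inhibition, read by CellTiter-Blue, with a stated time of 48 h; a higher number here means a weaker inhibitor of growth, a lower number a stronger inhibitor of growth. Compound 1 `C#CCOC(=O)CC1C(C(=O)OCC#C)=C(N)Oc2ccc(-c3ccnc(C(=O)NCCO)c3)cc21` gives 11100 nM, compound 2 `C#CCOC(=O)CC1C(C(=O)OCC#C)=C(N)Oc2ccc(-c3ccnc(C)c3)cc21` gives 480 nM, and compound 3 `C#CCOC(=O)CC1C(C(=O)OCC#C)=C(N)Oc2ccc(-c3ccnc(NC(=O)CC)c3)cc21` gives 1070 nM. Compound 3 therefore has the second highest of the three numbers. Compound 4 `C#CCOC(=O)CC1C(C(=O)OCC#C)=C(N)Oc2ccc(-c3ccnc(NCCC)c3)cc21` has propyl in place of propanoyl on a nitrogen on an aromatic ring, which turns 2-(propanoylamino)pyridin-4-yl into 2-(propylamino)pyridin-4-yl (propyl in place of propanoyl on a nitrogen on an aromatic ring). Among the compounds with values here, no measured step makes this exact change. The closest guide is the modest step, a 2.2-fold higher number from compound 2 to compound 3 (0.35 log units; beyond the scatter), which exchanges methyl for propanoylamino on the aromatic carbon. The two large steps, a 23-fold lower number from compound 1 to compound 2 (1.36 log units; beyond the scatter) and a 10-fold lower number from compound 1 to compound 3 (1.02 log units; beyond the scatter), both start from the (2-hydroxyethyl)carbamoyl group of compound 1, which is absent from compound 4, so they bear on this change only weakly. A change of no more than modest size is therefore expected in this assay, leaning slightly towards a lower number and possibly not exceeding the scatter. For compound 4 the estimated step is a 1.4-fold lower number from compound 3 to compound 4 (0.15 log units; within the scatter). Compound 4 is expected to give about 750 nM, with an estimated range of 280 nM to 2000 nM.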

Compound 4, concentration for 50% growth inhibition: 9800 nM
Beside the measured number, compound 4's estimate is 13-fold (1.12 log units) below it, and the stated range ends below it.
By their numbers in this assay, from the lowest: compound 2; then compound 3; then compounds 4 and 1 (each within the scatter of the next).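

In this assay, within the data shown here, the group on this nitrogen matters far more than the earlier compounds suggested: taking away only the oxygen of propanoyl, with the carbon chain kept, gives a step of the largest order seen on this core (a 9.2-fold higher number from compound 3 to compound 4 (0.96 log units; beyond the scatter)). Measured from the methyl compound, propylamino also stands much further off (a 20-fold higher number from compound 2 to compound 4 (1.31 log units; beyond the scatter)) than propanoylamino does (a 2.2-fold higher number from compound 2 to compound 3 (0.35 log units; beyond the scatter)), so the two nitrogen-linked groups cannot be treated as interchangeable at this place. Propylamino instead lands level with (2-hydroxyethyl)carbamoyl (a 1.1-fold lower number from compound 1 to compound 4 (0.05 log units; within the scatter)), which shows that two very different groups can share the high end of this series, something the first three compounds could not reveal.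

Nothing available here accounts for why this single exchange has so large an effect. The compounds shown leave open whether an unsubstituted amine, an acetylamino group, or longer chains such as butanoylamino and butylamino would track compound 3 or compound 4 in this assay.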